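Acetyl in place of ethyl on the piperazine nitrogen

The source may report more compounds than this note shows. Statements on the series, on what has been measured and on what is new or still open speak of the compounds shown alone.

Compound 1 `CCN1CCN(S(=O)(=O)CCCN2CCC(CNC(=O)c3cccc4c3OCCO4)CC2)CC1` gives 0.0501 nM in an assay on isolated protein for inhibition of 5-hydroxytryptamine receptor 4 (Homo sapiens) (on this read-out higher numbers stand for weaker inhibition and lower numbers for stronger inhibition), the lowest of the three numbers at hand; its nearest neighbour is compound 3 `CCCS(=O)(=O)N1CCN(S(=O)(=O)CCCN2CCC(CNC(=O)c3cccc4c3OCCO4)CC2)CC1`, which gives 0.1 nM in this assay, a gap that stays within the scatter, while compound 2 `O=C(NCC1CCN(CCCS(=O)(=O)N2CCNCC2)CC1)c1cccc2c1OCCO2` gives 0.159 nM in this assay and lies furthest away. The two measured steps from compound 1 read a 3.2-fold higher number from compound 1 to compound 2 (0.50 log units; beyond the scatter) and a 2.0-fold higher number from compound 1 to compound 3 (0.30 log units; within the scatter).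

Compound 4 `CC(=O)N1CCN(S(=O)(=O)CCCN2CCC(CNC(=O)c3cccc4c3OCCO4)CC2)CC1` carries the change (acetyl in place of ethyl on an amine nitrogen in a ring). Among the compounds with values here, the step that bears most closely on it is the one to compound 3, where a propylsulfonyl in place of ethyl on the same ring nitrogen cost only a 2.0-fold higher number from compound 1 to compound 3 (0.30 log units; within the scatter); the step to compound 2, where hydrogen replaced the ethyl, was larger at a 3.2-fold higher number from compound 1 to compound 2 (0.50 log units; beyond the scatter). Since acetyl, like propylsulfonyl, keeps a non-basic substituent on that nitrogen, a small move toward a higher number, staying within the scatter, is expected: an estimated 1.6-fold higher number from compound 1 to compound 4 (0.20 log units; within the scatter). Compound 4 is therefore estimated at 0.08 nM in this assay, with a range from 0.03 nM to 0.25 nM.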

Compound 4, inhibition constant: 0.126 nM
For compound 4 the middle estimate is 1.6-fold (0.20 log units) below the measured one, and the stated range covers the measured number.
By their numbers in this assay, from the lowest: compounds 1, 3, 4 and 2 (each within the scatter of the next, the first and the last beyond it).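

The acetyl step is the second replacement of the ethyl on this ring nitrogen, after hydrogen, to go beyond the scatter in this assay (a 2.5-fold higher number from compound 1 to compound 4 (0.40 log units; beyond the scatter)), whereas propylsulfonyl stayed within it. Compound 4 cannot be separated from its two neighbours (a 1.3-fold higher number from compound 3 to compound 4 (0.10 log units; within the scatter); a 1.3-fold lower number from compound 2 to compound 4 (0.10 log units; within the scatter)), so acetyl, propylsulfonyl and hydrogen on this nitrogen give values that lie within the scatter of one another, and only the ethyl of compound 1 stands apart from acetyl and hydrogen. No measurement at hand explains why acetyl and ethyl differ here.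

On these data alone, whether a propyl or a cyclopropyl on this nitrogen would read like ethyl remains open. So does whether a benzoyl, or a chain ending in a carboxylic acid, would read like acetyl.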